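Taking the chloro off compound 2

This account rests on a few compounds, and the source may have more. Where it says the series, first, only, none or still open, it means among the compounds named here.

Measured in a functional assay on HeLa cells (Homo sapiens) for antiproliferative activity, read by spectrophotometry, with a stated time of 2 days; a higher number here means a weaker inhibitor of growth, a lower number a stronger inhibitor of growth:
Compound 1 `CN(c1cccc2c1CN(c1nc(Nc3ccc(C(F)(F)F)cc3)ncc1C(F)(F)F)C2)S(C)(=O)=O`: > 30000 nM, a limit and not a number
Compound 2 `CN(c1cccc2c1CN(c1nc(Nc3ccc(Cl)c(C(F)(F)F)c3)ncc1C(F)(F)F)C2)S(C)(=O)=O`: 11100 nM

For the measured compounds named here, compound 2 gives the only true number in this small set, 11100 nM. Compound 1 gives only a limit of the assay, > 30000 nM.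

Compound 3 `CN(c1cccc2c1CN(c1nc(Nc3cccc(C(F)(F)F)c3)ncc1C(F)(F)F)C2)S(C)(=O)=O` differs from compound 2 by hydrogen in place of chloro on an aromatic carbon, which leaves a 3-(trifluoromethyl)phenyl group: hydrogen in place of chloro on an aromatic carbon.

Going by the values given here, one measured step bears on this change: an at least 2.7-fold lower number from compound 1 to compound 2 (0.43 log units; beyond the scatter). It replaced 4-(trifluoromethyl)phenyl with 4-chloro-3-(trifluoromethyl)phenyl, so the chloro arrived while the trifluoromethyl group also changed place. On these data alone, that step therefore does not show the effect of the chloro alone, and its true size is unknown on one side.

Compound 3 shares the missing chloro with compound 1, so a move towards a higher number in this assay, meaning weaker growth inhibition, is expected. The expected change is a 1.8-fold higher number from compound 2 to compound 3 (0.26 log units; within the scatter). The estimated value for compound 3 is 20000 nM, with an expected range of 8000 nM to 40000 nM.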

Compound 3, concentration for 50% growth inhibition: 5300 nM
For compound 3 the middle estimate is 3.8-fold (0.58 log units) above the measured one, and the stated range ends above it.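

Taking off the chloro gives a 2.1-fold lower number from compound 2 to compound 3 (0.32 log units; beyond the scatter) in this assay, so at this position, ortho to a trifluoromethyl group, the chloro is not needed for growth inhibition, and in this pair hydrogen gives the stronger inhibitor. The earlier step could not separate the chloro from the shift of the trifluoromethyl group, but the comparison without any chloro can: 3-(trifluoromethyl)phenyl in place of 4-(trifluoromethyl)phenyl gives an at least 5.6-fold lower number from compound 1 to compound 3 (0.75 log units; beyond the scatter), which points to the place of the trifluoromethyl group, not the chloro, as the source of the gain over compound 1. The true size of that step stays open on one side, since compound 1 gives only a limit of the assay and not a number: the limit of > 30000 nM in this assay, at which 1 of the 3 values shown sits.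

At this position only chloro and hydrogen are shown, so it remains open whether a fluoro, a methyl group, a methoxy group or an amine would give stronger or weaker growth inhibition than hydrogen. On these data alone, it is also open whether removing the chloro would have the same effect if the trifluoromethyl group were replaced by another group, such as a nitrile.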